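The source may hold more compounds than are shown below. What is called first, only, known or untested is meant among the compounds shown, and "the series" means these compounds.

Among the compounds with values here, compound 1 (`COC(=O)C1=C(CN2CCCCC2)NC(c2nccs2)=NC1(C)c1ccc(F)cc1`) reads 282 ug/mL in a physicochemical assay for solubility, read by HPLC, in phosphate buffer, at pH 6.5 (a higher number here means a more soluble compound, a lower number a less soluble compound), and compound 2 (`COC(=O)C1=C(CN2CCC(O)CC2)NC(c2nccs2)=NC1(C)c1ccc(F)cc1`) reads 593 ug/mL there, while compound 3 (`COC(=O)C1=C(CN2CCCS2(=O)=O)NC(c2nccs2)=NC1(C)c1ccc(F)cc1`) stands lowest of the three at 125 ug/mL in this assay so far. Compound 4 (`COC(=O)C1=C(COC(C(=O)O)C(F)(F)F)NC(c2nccs2)=NC1(C)c1ccc(F)cc1`) differs from compound 3 by one change (a group of 9 heavy atoms (3 carbon, 3 oxygen, 3 fluorine; no ring) in place of a group of 7 heavy atoms (3 carbon, 1 nitrogen, 2 oxygen, 1 sulfur; one five-membered non-aromatic ring with 2 hetero atoms), on a saturated chain carbon bound to a double-bonded ring carbon). Within the data shown here, two measured steps touch this place, a 2.3-fold lower number from compound 1 to compound 3 (0.35 log units; beyond the scatter) and a 4.7-fold lower number from compound 2 to compound 3 (0.68 log units; beyond the scatter), and both are modest yet beyond the scatter. A third, a 2.1-fold higher number from compound 1 to compound 2 (0.32 log units; beyond the scatter), is also modest. None of them involves the entering group, so they guide only loosely. With compound 3 at the bottom, a modest rise is expected, namely a 4.0-fold higher number from compound 3 to compound 4 (0.60 log units; beyond the scatter) as an estimated step. For compound 4 the expected value is 500 ug/mL, with an estimated range of 150 ug/mL to 1500 ug/mL in this measurement.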

Compound 4, solubility: > 649 ug/mL
Compound 4: no number, only a limit (the forecaster's own chance of this, stated with the estimate: 15%); at least 1.2-fold (0.11 log units) between middle value and limit.
By their numbers in this assay, from the lowest: compound 3; then compound 1; then compound 2. At a limit, above all of these: compound 4.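

In this assay compound 4 gives only a limit, not a number: the limit of > 649 ug/mL in this assay, at which 1 of the 4 values shown sits. On a saturated chain carbon bound to a double-bonded ring carbon, a group with no ring and no nitrogen still gives a rise over both earlier ring groups (an at least 5.1-fold higher number from compound 3 to compound 4 (0.71 log units; beyond the scatter); an at least 2.3-fold higher number from compound 1 to compound 4 (0.36 log units; beyond the scatter)). The third step (an at least 1.0-fold higher number from compound 2 to compound 4 (0.03 log units; that floor lies within the scatter)) cannot be read as an order.

The compounds shown leave open which part of the entering group goes with this rise, as none separates the carboxylic acid from the trifluoromethyl. On these data alone, how a primary amide or a methyl ester in place of the acid would read also stays open.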